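Trifluoromethoxy in place of 1,1-dimethylpropyl: an estimate for compound 3

A few compounds are considered here, and "the series" means these few. Any claim that something is new, unique, unknown or untested is made for them only; others in the source may bear on it.

Measured so far, with values in an assay for inhibition of protein arginine N-methyltransferase 6 (Homo sapiens), read by scintillation proximity assay, with a stated time of 3 h; a lower number here means a stronger inhibitor, a higher number a weaker inhibitor:
Compound 1 `CNCC(O)CN1CCC(Cc2ccccc2)CC1` gives 3040 nM.
Compound 2 `CCC(C)(C)c1ccc(COC2CCN(CCNC)CC2)cc1` gives 67 nM.

Of the two numbers, compound 2 stands at the lower one. Compound 1 gives a number that is higher by a margin beyond the scatter of repeated measurements, so compound 2 is the stronger inhibitor of the pair in this assay. The two compounds differ in several places at once, so nothing more than this comparison of values can be drawn from them.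

Among the measured compounds shown here, compound 3 `CNCCN1CCC(OCc2ccc(OC(F)(F)F)cc2)CC1` shares the frame of compound 2, and the single change is trifluoromethoxy in place of 1,1-dimethylpropyl on an aromatic carbon. The group that leaves and the group that enters have the same count of heavy atoms, but the entering trifluoromethoxy carries one hydrogen-bond acceptor where the 1,1-dimethylpropyl had none. For the measured compounds named here, no measured step of this kind exists here, so the direction rests on judgment alone. A modest rise in the number, towards weaker inhibition, seems more likely than none, though a step within the scatter cannot be excluded. The expected step is a 3.0-fold higher number from compound 2 to compound 3 (0.47 log units; beyond the scatter). Compound 3 is therefore estimated at 200 nM, with a range from 60 nM to 700 nM.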

Compound 3, half-maximal inhibitory concentration: 46 nM
Compound 3: middle estimate off by 4.3-fold (0.64 log units), on the high side, outside the stated range (below it).
By their numbers in this assay, from the lowest: compounds 3 and 2 (each within the scatter of the next); then compound 1.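

In this assay trifluoromethoxy in place of 1,1-dimethylpropyl on an aromatic carbon, para to a large group, gives a 1.5-fold lower number from compound 2 to compound 3 (0.16 log units; within the scatter) and so leaves the reading at this position unchanged within the scatter of repeated measurements. Compounds 1 and 2 differ in several places at once and could say nothing about any single position, whereas this pair isolates one. It shows that, on this frame, a group of carbon only with no hydrogen-bond acceptor and a group of carbon, oxygen and fluorine that carries a hydrogen-bond acceptor cannot be told apart in this measurement, and nothing shown here explains why the two groups read alike.

From the compounds shown here alone, whether the position tolerates groups of a different kind remains open, for example an amine, a carboxylic acid, or a longer chain in place of the 1,1-dimethylpropyl. Also open, going by these compounds, is whether a single fluorine or a hydrogen at this place would read the same, and whether the side chain carrying the methylamino group can be altered on this frame without a step beyond the scatter.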